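Replacing the carboxy group of compound 3

The source may report more compounds than this note shows. Statements on the series, on what has been measured and on what is new or still open speak of the compounds shown alone.

In a functional assay on the whole organism (strain Sprague-Dawley) for inhibition, with Rattus norvegicus as the target, with a stated time of 10 min (on this read-out lower numbers stand for an effect already at smaller amounts and higher numbers for an effect only at larger amounts of compound), compound 1 `CCOc1ccccc1-c1ncc(C(=O)O)c(=O)[nH]1` gives 0.5 mg/kg and compound 2 `CCCOc1ccccc1-c1ncc(C(=O)O)c(=O)[nH]1` gives 0.9 mg/kg. Compound 3 `CCOc1ccc(C(=O)O)cc1-c1ncc(C(=O)O)c(=O)[nH]1` has the highest number of the three, at 25 mg/kg. Compound 4 `CCOc1ccc(N(C)C)cc1-c1ncc(C(=O)O)c(=O)[nH]1` carries dimethylamino in place of carboxy on an aromatic carbon, para to an ethoxy group (dimethylamino in place of carboxy on an aromatic carbon). Two measured steps give context. Adding a methyl to the chain gave only a 1.8-fold higher number from compound 1 to compound 2 (0.26 log units; within the scatter), while adding the carboxy gave a 50-fold higher number from compound 1 to compound 3 (1.70 log units; beyond the scatter). Within the data shown here, compound 4 lacks that carboxy, so a lower number is expected, although no measured compound shows what dimethylamino does at this place. The expected change is a 13-fold lower number from compound 3 to compound 4 (1.10 log units; beyond the scatter), undoing most of the earlier rise. For compound 4 the estimated value is 2 mg/kg, within a range of 0.4 mg/kg to 10 mg/kg.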

Compound 4, dose for 50% inhibition: 0.3 mg/kg
Estimate against measurement, compound 4: 6.7-fold (0.82 log units) above; measured number outside the range, below it.
By their numbers in this assay, from the lowest: compounds 4, 1 and 2 (each within the scatter of the next, the first and the last beyond it); then compound 3.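

At this aromatic carbon, para to an ethoxy group, a substituent need not cost activity. In this assay, dimethylamino in place of carboxy gives an 83-fold lower number from compound 3 to compound 4 (1.92 log units; beyond the scatter), while dimethylamino in place of hydrogen gives a 1.7-fold lower number from compound 1 to compound 4 (0.22 log units; within the scatter), so the large rise in the number is tied to carboxy rather than to any group placed here. Nothing available accounts for this difference between the two groups. Open, from the compounds shown here alone, is whether a primary amine, a methyl ester or a longer chain on the nitrogen would be tolerated at this place as well.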